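Swapping Methyl for 1,1-Difluoroethyl Ahead of Measurement

The source may hold more compounds than are shown below. What is called first, only, known or untested is meant among the compounds shown, and "the series" means these compounds.

Of the compounds shown here, two have so far been measured in an assay on cells for inhibition of cytochrome P450 11B2, mitochondrial (Homo sapiens), read by HPLC, with a stated time of 90 min; a higher number here means a weaker inhibitor, a lower number a stronger inhibitor. Compound 1 `Fc1ccc2nc(-c3cccnn3)n(C3CC3)c2c1` gives 412 nM in this assay. Compound 2 `Cc1ncncc1-c1nc2cc(F)c(F)cc2n1C1CC1` gives 17 nM in this assay, the lower of the two numbers, and the gap to compound 1 lies beyond the usual scatter of repeated measurements, so compound 2 is the stronger inhibitor of the pair.

Compound 3 `CC(F)(F)c1ncncc1-c1nc2cc(F)c(F)cc2n1C1CC1` has not yet been measured. It differs from compound 2 in a single place: 1,1-difluoroethyl in place of methyl on an aromatic carbon. Among the measured compounds shown here, no measured pair of compounds shows this particular change, so the numbers at hand give no direct guide to its size or direction. The account therefore rests on compound 2 alone as the starting point.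

The author expects the step from compound 2 to compound 3 in this assay, a 1.8-fold higher number from compound 2 to compound 3 (0.25 log units; within the scatter), to be small, most likely within the scatter or a modest weakening. For compound 3 the author estimates 30 nM in this assay, with a range from 8 nM to 120 nM.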

Compound 3, half-maximal inhibitory concentration: 50 nM
The estimate for compound 3 lay 1.7-fold (0.22 log units) below the measured number; measured number inside the range.
By their numbers in this assay, from the lowest: compound 2; then compound 3; then compound 1.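

In this assay, among the compounds shown here, the change from methyl to 1,1-difluoroethyl gives a 2.9-fold higher number from compound 2 to compound 3 (0.47 log units; beyond the scatter), the first direct reading of any change at this place on the aromatic ring, since compound 1 and compound 2 differ in more than one place. The step shows that this place, ortho to a large group, responds to what sits on it, yet it accepts a group of 4 heavy atoms in place of 1 at a modest cost: compound 3, at 50 nM, keeps much of the inhibition seen with compound 2. Nothing measured here gives a reason for this step.

For the compounds shown here, the single step cannot separate the contribution of the added carbon from that of the two fluorine atoms, and an ethyl or a trifluoromethyl group at this place would be needed to tell them apart. The compounds shown also leave open how a bare hydrogen, a methoxy group or an amine on this carbon would read in this assay, and so whether methyl is the best of the small groups here.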